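A few compounds are considered here, and "the series" means these few. Any claim that something is new, unique, unknown or untested is made for them only; others in the source may bear on it.

Among the measured compounds shown here, compound 3 `CC1(C)[C@@H]2CC[C@@]1(CS(=O)(=O)N1CCN(c3ccc(C(F)(F)F)nn3)CC1)C(=O)C2` is the one member of this small set with a number in a functional assay on CHO-K1 cells for antagonist activity at C-X-C chemokine receptor type 3 (Homo sapiens), read by FLIPR and calcium flux; on this read-out higher numbers stand for weaker inhibition and lower numbers for stronger inhibition: compound 3 gives 5010 nM. Compound 1 `CC1(C)[C@@H]2CC[C@@]1(CS(=O)(=O)N1CCN(c3ccccn3)CC1)C(=O)C2` reaches only a limit, > 31600 nM. Compound 2 `CC1(C)[C@@H]2CC[C@@]1(CS(=O)(=O)N1CCN(c3ccc([N+](=O)[O-])cn3)CC1)C(=O)C2` likewise reaches only a limit, > 31600 nM. Both sit at the limit of > 31600 nM in this assay, at which 2 of the 3 values shown sit, so the step that the two limits leave unreadable from compound 1 to compound 2 cannot be read, whereas an at least 6.3-fold lower number from compound 1 to compound 3 (0.79 log units; beyond the scatter) and an at least 6.3-fold lower number from compound 2 to compound 3 (0.79 log units; beyond the scatter) are both at least modest. Compound 4 `CC1(C)[C@@H]2CC[C@@]1(CS(=O)(=O)N1CCN(c3cc4ccccc4cn3)CC1)C(=O)C2` carries isoquinolin-3-yl in place of 6-(trifluoromethyl)pyridazin-3-yl on an amine nitrogen in a ring. Going by these compounds, the two readable steps show that exchanging the aromatic ring on the ring amine nitrogen can shift the number at least modestly, but neither involves an isoquinolinyl group, so the direction for compound 4 stays open. Compound 4 is expected to give 8000 nM, between 1500 nM and 31600 nM, an estimated step of a 1.6-fold higher number from compound 3 to compound 4 (0.20 log units; within the scatter).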

Compound 4, half-maximal inhibitory concentration: 15800 nM
For compound 4 the middle estimate is 2.0-fold (0.30 log units) below the measured one, and the stated range covers the measured number.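

With compound 4 there are two real numbers at this place on the ring amine nitrogen, and in this assay isoquinolin-3-yl, with the same heavy-atom count as 6-(trifluoromethyl)pyridazin-3-yl, gives a 3.2-fold higher number from compound 3 to compound 4 (0.50 log units; beyond the scatter). Against the other two compounds, the exchange gives an at least 2.0-fold lower number from compound 2 to compound 4 (0.30 log units; that floor lies within the scatter) and an at least 2.0-fold lower number from compound 1 to compound 4 (0.30 log units; that floor lies within the scatter). Both of these steps rest on a value that is a limit of the assay: the limit of > 31600 nM in this assay, at which 2 of the 4 values shown sit.

Still open, going by these compounds, is how a pyrimidin-2-yl or 4-fluorophenyl group would read at this place. Also open, on these data alone, is whether trifluoromethyl on the isoquinolin-3-yl group would lower the number.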